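Removing the chloro from the outer phenyl ring

A few compounds are considered here, and "the series" means these few. Any claim that something is new, unique, unknown or untested is made for them only; others in the source may bear on it.

Compound 2 `N=C(N)c1ccc(-c2ccc(-c3ccc(Cl)cc3)s2)cc1F` stands lowest of the two numbers shown: in a functional assay on OVCAR-3 cells (Homo sapiens) for inhibition, read by sulforhodamine B assay, with a stated time of 48 h (on this read-out higher numbers stand for weaker inhibition of growth and lower numbers for stronger inhibition of growth), compound 2 gives 268 nM. Compound 1 `N=C(N)c1ccc(-c2ccc(-c3cc(Cl)cc(Cl)c3)s2)cc1` differs from it in more than one place; in this assay compound 1 gives 1700 nM, a gap beyond the scatter. Compound 3 `N=C(N)c1ccc(-c2ccc(-c3ccccc3)s2)cc1F` differs from compound 2 in one place: hydrogen in place of chloro on an aromatic carbon. Going by the values given here, no step between measured compounds isolates this change, so the direction rests on the structures alone. Compound 3 is expected to come out somewhat weaker, with an estimated step of a 2.4-fold higher number from compound 2 to compound 3 (0.38 log units; beyond the scatter). The estimate for compound 3 is 650 nM, between 220 nM and 2000 nM.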

Compound 3, concentration for 50% growth inhibition: 8900 nM
Compound 3: middle estimate off by 14-fold (1.14 log units), on the low side, outside the stated range (above it).
By their numbers in this assay, from the lowest: compound 2; then compound 1; then compound 3.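

Replacing chloro with hydrogen on the aromatic carbon para to a large group gives a 33-fold higher number from compound 2 to compound 3 (1.52 log units; beyond the scatter) in this assay, a large step beyond the scatter. Going by these compounds alone, it is the first step here that isolates one change, and it shows that growth inhibition depends strongly on the chloro at this place. Nothing measured here explains the size of this step. Within the data shown here, it remains open whether chloro is the only group that serves at this place. A bromo, a methoxy or an amine there could fall near compound 2 or near compound 3.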